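The source may hold more compounds than are shown below. What is called first, only, known or untested is meant among the compounds shown, and "the series" means these compounds.

Measured compounds, in an assay on isolated protein (strain Sprague-Dawley) for inhibition of Amine oxidase [flavin-containing] B (Rattus norvegicus), read by spectrophotometry, with a stated time of 5 min; a lower number here means a stronger inhibitor, a higher number a weaker inhibitor: compound 1 `CNC(=O)COc1cc(=O)oc2cc(OCc3cccc(Cl)c3)ccc12` gives 33.9 nM; compound 2 `O=C(COc1cc(=O)oc2cc(OCc3cccc(Cl)c3)ccc12)N1CCCCC1` gives 38900 nM; compound 3 `CCOC(=O)Nc1cc(=O)oc2cc(OCc3cccc(Cl)c3)ccc12` gives 589 nM.

Compound 3 stands second highest of the three: a 17-fold higher number from compound 1 to compound 3 (1.24 log units; beyond the scatter), while a 66-fold lower number from compound 2 to compound 3 (1.82 log units; beyond the scatter). Compound 4 `CCNc1cc(=O)oc2cc(OCc3cccc(Cl)c3)ccc12` differs from compound 3 by ethyl in place of ethoxycarbonyl on a nitrogen on an aromatic ring. Within the data shown here, no measured step alters the group on this nitrogen alone; the steps known here (a 1100-fold higher number from compound 1 to compound 2 (3.06 log units; beyond the scatter), and the two side-chain swaps above) exchange whole substituents on the core, so they bear on the question only loosely. Smaller substituents have not hurt, given compound 1 at 33.9 nM, so a modest step downward is expected, with wide uncertainty: a 2.0-fold lower number from compound 3 to compound 4 (0.29 log units; within the scatter). Compound 4 is estimated at 300 nM, range 60 nM to 1500 nM.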

Compound 4, half-maximal inhibitory concentration: 28.2 nM
For compound 4 the middle estimate is 11-fold (1.03 log units) above the measured one, outside the stated range (below it).
By their numbers in this assay, from the lowest: compounds 4 and 1 (each within the scatter of the next); then compound 3; then compound 2.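

In this assay, among these compounds, ethyl in place of ethoxycarbonyl on the nitrogen gives the only measured change confined to this substituent (a 21-fold lower number from compound 3 to compound 4 (1.32 log units; beyond the scatter)), so the carbonyl-bearing group is not needed for a low number here. The small ethylamino group stands level with the (methylcarbamoyl)methoxy group (a 1.2-fold lower number from compound 1 to compound 4 (0.08 log units; within the scatter)) and far ahead of the ((piperidin-1-yl)carbonyl)methoxy group (a 1400-fold lower number from compound 2 to compound 4 (3.14 log units; beyond the scatter)), though both comparisons exchange whole substituents. No measured evidence on the origin of these steps is available. Still open, on these data alone, is whether an unsubstituted amine, a methyl group or a longer chain such as propyl on this nitrogen keeps this level.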